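The source may report more compounds than this note shows. Statements on the series, on what has been measured and on what is new or still open speak of the compounds shown alone.

Compound 2 `COc1cccc(C2=NN(C(=S)Nc3ccccc3)C(c3ccc4c(c3)OCCO4)C2)c1` gives 2920 nM in a functional assay on HT-29 cells (Homo sapiens) for antiproliferative activity, read by MTT assay, with a stated time of 48 h; a lower number here means a stronger inhibitor of growth, a higher number a weaker inhibitor of growth. It stands beside compound 1 `S=C(Nc1ccccc1)N1N=C(c2ccc(Br)cc2)CC1c1ccc2c(c1)OCCO2`, which gives 2580 nM, and the two numbers lie within the scatter of one another, so no order can be read between them. Compound 3 `S=C(Nc1ccccc1)N1N=C(c2ccc(Cl)c(Cl)c2)CC1c1ccc2c(c1)OCCO2` has not yet been measured; it differs from compound 2 by 3,4-dichlorophenyl in place of 3-methoxyphenyl on a carbon with a double bond to nitrogen. For the measured compounds named here, the only step at this place, a 1.1-fold higher number from compound 1 to compound 2 (0.05 log units; within the scatter), stayed within the scatter. On that basis the step of a 1.1-fold lower number from compound 2 to compound 3 (0.03 log units; within the scatter) is expected to be small, with no clear direction. Compound 3 is therefore estimated at 2700 nM, with a range from 1300 nM to 5800 nM.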

Compound 3, concentration for 50% growth inhibition: 95300 nM
Estimate against measurement, compound 3: 35-fold (1.55 log units) below, outside the stated range (above it).
By their numbers in this assay, from the lowest: compounds 1 and 2 (each within the scatter of the next); then compound 3.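

This position is not indifferent to its substituent, even though 3-methoxyphenyl and 4-bromophenyl could not be told apart there. Placing 3,4-dichlorophenyl on the carbon with a double bond to nitrogen gives a 33-fold higher number from compound 2 to compound 3 (1.51 log units; beyond the scatter) and a 37-fold higher number from compound 1 to compound 3 (1.57 log units; beyond the scatter) with the rest of the molecule unchanged, so growth inhibition is much weaker. Nothing available explains this loss. The compounds shown leave open whether 4-chlorophenyl, with a single chlorine, would behave like 4-bromophenyl or like 3,4-dichlorophenyl. From the compounds shown here alone, how a phenyl ring carrying an amine or a carboxylic acid would fare here also remains open.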